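A Chloro-to-Hydrogen Step Measured Against Cell Toxicity

A few compounds are considered here, and "the series" means these few. Any claim that something is new, unique, unknown or untested is made for them only; others in the source may bear on it.

The study covers two measured compounds and one that awaits measurement. Compound 1 `COc1ccc(OC)c(/C=C/c2nnc(Nc3ccc(Cl)cc3)o2)c1` was tested in a functional assay on LOX IMVI cells (Homo sapiens) for antiproliferative activity, read by sulforhodamine B assay, with a stated time of 48 h; on this read-out lower numbers stand for higher toxicity in this test and higher numbers for lower toxicity in this test; compound 1 gives > 100000 nM, which is a limit of the assay rather than a number. Compound 2 `COc1ccc(OC)c(/C=C/C(=O)N/N=C/c2ccc(Cl)cc2)c1` likewise reached only a limit in this assay: compound 2 gives > 100000 nM. the limit of > 100000 nM in this assay, at which 2 of the 2 values shown sit, sums up where both values sit, so compound 2 cannot be ranked against any other compound on the numbers shown. Going by the values given here, no pair of measured compounds differs in a single place, so no measured step exists to guide the next move.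

Compound 3 `COc1ccc(OC)c(/C=C/C(=O)N/N=C/c2ccccc2)c1` differs from compound 2 by hydrogen in place of chloro on an aromatic carbon. Among the compounds with values here, with no measured step to lean on, the chemist expects this change to shift this assay by nothing beyond the scatter, and most likely compound 3 will again return only a limit. The estimate for compound 3 in this assay is 150000 nM, with a range from 50000 nM to 500000 nM. The step from compound 2 to compound 3 implied by this estimate is a step that the limit leaves unreadable from compound 2 to compound 3, expected to be small.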

Compound 3, concentration lethal to 50% of the cells: > 100000 nM
Compound 3: no number, only a limit; the forecaster's own chance of this, stated with the estimate: 85%; the middle value does not contradict the limit.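

In this assay compound 3 gives > 100000 nM, which is a limit of the assay and not a number. Going by these compounds alone, compound 2 and compound 3 both return only a limit, and no step between them can be read. The compounds shown leave open what the change from 4-chlorophenyl to phenyl does to cell toxicity, and one reading covers them all: the limit of > 100000 nM in this assay, at which 3 of the 3 values shown sit.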